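The source may report more compounds than this note shows. Statements on the series, on what has been measured and on what is new or still open speak of the compounds shown alone.

In a functional assay on JeKo-1 cells (Homo sapiens) for antiproliferative activity (a lower number here means a stronger inhibitor, a higher number a weaker inhibitor), compound 2 `Nc1ncnc2c1c(-c1cc3ccccc3o1)cn2[C@H]1CCN(C[C@@H]2CO2)C1` gives 2820 nM, within the scatter of compound 1 `Nc1ncnc2c1c(-c1ccc(C(=O)Nc3ccc(Oc4ccccc4)cc3)cc1)cn2[C@H]1CCN(C[C@@H]2CO2)C1` at 2070 nM, while compound 3 `Nc1ncnc2c1c(-c1cc3ccccc3o1)cn2[C@H]1CCN(C[C@H]2CO2)C1` lies lower at 630 nM. Going by the values given here, the only measured step, a 4.5-fold lower number from compound 2 to compound 3 (0.65 log units; beyond the scatter), is due to the fact that compounds 2 and 3 differ only in the configuration as drawn, so it gives no size for a change of the group on the aromatic carbon. Compound 4 `Nc1ncnc2c1c(-c1cnc3[nH]ccc3c1)cn2[C@H]1CCN(C[C@@H]2CO2)C1` keeps the configuration of compound 2 and replaces its 1-benzofuran-2-yl group: a group of 9 heavy atoms (7 carbon, 2 nitrogen; one five-membered aromatic ring with 1 hetero atom, one six-membered aromatic ring with 1 hetero atom) in place of a group of 9 heavy atoms (8 carbon, 1 oxygen; one five-membered aromatic ring with 1 hetero atom, one six-membered aromatic ring of carbon only), on an aromatic carbon. Compound 1, with a different group at that place, gives 2070 nM, which suggests that such a swap need not move the number much. No change beyond the scatter is therefore expected in this assay, in either direction. The expected step is a 1.1-fold higher number from compound 2 to compound 4 (0.03 log units; within the scatter). Compound 4 is estimated at 3000 nM, with an expected range of 800 nM to 10000 nM.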

Compound 4, half-maximal inhibitory concentration: 9440 nM
For compound 4 the middle estimate is 3.1-fold (0.50 log units) below the measured one; low and high end bracket the measured number.
By their numbers in this assay, from the lowest: compound 3; then compounds 1 and 2 (each within the scatter of the next); then compound 4.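

In this assay, the group on this aromatic carbon does matter: replacing 1-benzofuran-2-yl gives a 3.3-fold higher number from compound 2 to compound 4 (0.52 log units; beyond the scatter). The two groups have the same count of heavy atoms and the same ring sizes, so a change in ring atoms alone, with size held constant, is enough to shift the number. Nothing shown here explains why the number rises.

As far as these compounds go, it remains open whether the configuration of compound 3 would also lower the number with the group of compound 4. From the compounds shown here alone, it is also open what a plain phenyl ring or an amine would give on this carbon.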